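Fluoro on the benzyl ring of compound 1

The source may report more compounds than this note shows. Statements on the series, on what has been measured and on what is new or still open speak of the compounds shown alone.

Measured compounds in a functional assay on the whole organism with Canis familiaris (Canis lupus familiaris) as the target, at a dose of 8 mg/kg by the oral route; on this read-out lower numbers stand for a weaker effect and higher numbers for a stronger effect at the one dose given:
compound 1 `Cc1nc2c(OCc3ccccc3)cccn2c1N` gives 96%
compound 2 `CCCc1nc2c(OCc3ccccc3)cccn2c1N` gives 0%
compound 3 `CCCCc1nc2c(OCc3ccccc3)cccn2c1N` gives 0%

Compound 1 holds the highest of the three numbers. The step of a number 96 percentage points lower from compound 1 to compound 2 (beyond the scatter) and the step of a number 96 percentage points lower from compound 1 to compound 3 (beyond the scatter) both lie far beyond the scatter, while the step of no change at the digits printed from compound 2 to compound 3 (within the scatter) stays within it. Every measured step thus concerns the chain on the saturated chain carbon bound to an aromatic carbon of the shared core; nothing measured touches the benzyl ring.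

Compound 4 `Cc1nc2c(OCc3ccccc3F)cccn2c1N` differs from compound 1 by fluoro in place of hydrogen on an aromatic carbon, placed on an aromatic carbon of a six-membered aromatic ring of carbon only, ortho to a large group. Among the measured compounds shown here, no measured step bears on this change; the large chain-length steps speak to another site. A change within the scatter in this assay is therefore expected: a number 8 percentage points lower from compound 1 to compound 4 (within the scatter). The range is skewed toward lower numbers because compound 1 already gives 96% and the scale ends not far above. Compound 4 is expected to give 88%, between 55% and 99%.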

Compound 4, a percentage reported as inhibition, in the whole organism at one dose (the size of the read-out at that dose, not a potency): 93%
Compound 4: the middle estimate sits 5 percentage points below what was measured; the range from low to high includes it.
By their numbers in this assay, from the lowest: compounds 2 and 3 (each within the scatter of the next); then compounds 4 and 1 (each within the scatter of the next).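

In this assay, fluoro in place of hydrogen on an aromatic carbon of the benzyl ring, ortho to a large group, gives a number 3 percentage points lower from compound 1 to compound 4 (within the scatter). Among the compounds shown here, this is the first measured change on that ring, and unlike the chain step of a number 96 percentage points lower from compound 1 to compound 2 (beyond the scatter), it leaves the read-out within the scatter, so this position accepts fluoro at the one dose given. No supporting evidence accounts for this result.

As far as these compounds go, whether a larger group at the same place, such as chloro or methoxy, also keeps the read-out remains open, as does the effect of fluoro elsewhere on the ring. From the compounds shown here alone, on the chain side, an ethyl chain in place of the methyl of compound 1 remains open too.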